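Exchanging a hydroxy for a chloro on the outer phenyl ring

A few compounds are considered here, and "the series" means these few. Any claim that something is new, unique, unknown or untested is made for them only; others in the source may bear on it.

Compound 1 `COc1ccc(C(=O)/C=C/c2cc3ccccc3[nH]c2=O)cc1` and compound 2 `O=C(/C=C/c1cc2ccccc2[nH]c1=O)c1ccc(O)cc1` share one core and differ only in the group on the outer phenyl ring. In an ADME assay on SF-295 cells (Homo sapiens) for cytotoxicity, read by sulforhodamine B assay, with a stated time of 24 h (on this read-out lower numbers stand for higher toxicity in this test and higher numbers for lower toxicity in this test), compound 1 gives 80800 nM. Compound 2 gives only a limit of the test, > 100000 nM, sitting at the limit of > 100000 nM in this assay, at which 1 of the 2 values shown sits. The step of an at least 1.2-fold higher number from compound 1 to compound 2 (0.09 log units; that floor lies within the scatter) thus rests on that limit and is small in any case. Compound 3 `O=C(/C=C/c1cc2ccccc2[nH]c1=O)c1ccc(Cl)cc1` is not yet measured, and its difference from compound 2 is chloro in place of hydroxy on an aromatic carbon. Going by the values given here, no measured step covers this exchange of hydroxy for chloro, and the single known step stays within the scatter, so there is no ground for expecting a shift in either direction beyond it. The expected step of a number no higher from compound 2 to compound 3 (the limit leaves the size open) is therefore essentially flat. For compound 3 the estimate in this assay is 100000 nM, with a range from 40000 nM to 250000 nM. For compound 3 the read-out may again come back only as a limit.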

Compound 3, concentration lethal to 50% of the cells: > 100000 nM
Compound 3: only a limit was reported; the forecaster's own chance of this, stated with the estimate: 55%; the middle value lies on the limit itself.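

In this assay, compound 3 is reported only as a limit, as compound 2 was, so the step between these two cannot be read. Going by these compounds alone, the one readable new step is an at least 1.2-fold higher number from compound 1 to compound 3 (0.09 log units; that floor lies within the scatter), and it rests on a limit too, so chloro in place of methoxy on this aromatic carbon, para to a large group, shows no change beyond the scatter. What is new is that replacing hydroxy, with its hydrogen-bond donor and acceptor, by chloro, which has neither, still gives no value inside the range of the test, so the result joins the others at the same limit: the limit of > 100000 nM in this assay, at which 2 of the 3 values shown sit.

As far as these compounds go, how far compounds 2 and 3 lie past that limit remains unknown. From the compounds shown here alone, it also remains open whether an amine or a carboxylic acid at this position would give a value that can be read.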